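The source may report more compounds than this note shows. Statements on the series, on what has been measured and on what is new or still open speak of the compounds shown alone.

Measured so far in a toxicity assay on GES1 cells (Homo sapiens) for inhibition, read by MTT assay, with a stated time of 72 h; a lower number here means a stronger inhibitor, a higher number a weaker inhibitor:
- Compound 1 `Cc1cc(N2CC[C@@H](C)[C@@H](N(C)c3ncnc4[nH]ccc34)C2)n2nc(SCc3ccc(F)cc3)nc2n1` gives 12300 nM
- Compound 2 `Cc1cc(N2CC[C@@H](C)[C@@H](N(C)c3ncnc4[nH]ccc34)C2)n2nc(SCC3CCCCC3)nc2n1` gives 98200 nM
- Compound 3 `C=CCSc1nc2nc(C)cc(N3CC[C@@H](C)[C@@H](N(C)c4ncnc5[nH]ccc45)C3)n2n1` gives > 100000 nM

The entry for compound 3 is a limit of the assay and not a number. Compound 3 stands at the limit of > 100000 nM in this assay, at which 1 of the 3 values shown sits, so its position is known only as a limit.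

Compound 4 `Cc1cc(N2CC[C@@H](C)[C@@H](N(C)c3ncnc4[nH]ccc34)C2)n2nc(SCc3ccc([N+](=O)[O-])cc3)nc2n1` is the next structure, with 4-nitrophenyl in place of vinyl on a saturated chain carbon bound to a sulfur.

The nearest evidence is an at least 8.1-fold higher number from compound 1 to compound 3 (0.91 log units; beyond the scatter), which covers the same place with 4-fluorophenyl against vinyl. Read in reverse, it points to a lower number on bringing in an aromatic ring. The step of an 8.0-fold higher number from compound 1 to compound 2 (0.90 log units; beyond the scatter) also favours the aromatic ring over cyclohexyl, whereas an at least 1.0-fold higher number from compound 2 to compound 3 (0.00 log units; that floor lies within the scatter) separates nothing. Only compound 1 supports the aromatic case, so a drop of about that modest size is expected in this assay. The expected change is an at least 6.6-fold lower number from compound 3 to compound 4 (0.82 log units; beyond the scatter). Compound 4 is estimated at 15000 nM, within an expected range of 5000 nM to 45000 nM.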

Compound 4, half-maximal inhibitory concentration: 36600 nM
For compound 4 the middle estimate is 2.4-fold (0.39 log units) below the measured one; low and high end bracket the measured number.
By their numbers in this assay, from the lowest: compound 1; then compound 4; then compound 2. At a limit, above all of these: compound 3.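

In this assay, a second aromatic group on a saturated chain carbon bound to a sulfur also lowers the number, with an at least 2.7-fold lower number from compound 3 to compound 4 (0.43 log units; beyond the scatter) and a 2.7-fold lower number from compound 2 to compound 4 (0.43 log units; beyond the scatter), so compound 1 no longer stands alone as the aromatic case. The group on the ring counts as well: nitro in place of fluoro on an aromatic carbon gives a 3.0-fold higher number from compound 1 to compound 4 (0.47 log units; beyond the scatter), so the presence of an aromatic ring does not alone set the number. The entry for compound 3 is a limit of the assay and not a number: the limit of > 100000 nM in this assay, at which 1 of the 4 values shown sits.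

The compounds shown leave open how other groups on that ring, such as a methoxy group or an amine, would compare with nitro and fluoro. They also leave open whether a longer chain between the sulfur and the ring would move the number.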